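This account rests on a few compounds, and the source may have more. Where it says the series, first, only, none or still open, it means among the compounds named here.

Compound 1 `Cc1cccc(-c2nnc([C@H](C)NC(=O)c3cc(C4CC4)nn3C)o2)c1` gives > 30000 nM in an assay on T-REx-293 cells for inhibition of potassium channel subfamily T member 1 (Homo sapiens), read by patch clamp; a higher number here means a weaker inhibitor, a lower number a stronger inhibitor; this value is a limit of the assay, not a number.
Compound 2 `Cc1cccc(-c2noc([C@H](C)NC(=O)c3cc(C(F)(F)F)nn3C)n2)n1` gives > 30000 nM in this assay; this value too is a limit of the assay.

Compound 2 therefore stands at the limit of > 30000 nM in this assay, at which 2 of the 2 values shown sit, and no number places it further. For the measured compounds named here, no measured pair differing in a single place is at hand, so no step size is known. Compound 3 `COCc1cc(-c2noc([C@H](C)NC(=O)c3cc(C(F)(F)F)nn3C)n2)ccn1` carries 2-(methoxymethyl)pyridin-4-yl in place of 6-methylpyridin-2-yl on an aromatic carbon. With both known compounds at the limit, the expected step of a number no higher from compound 2 to compound 3 (the limit leaves the size open) is none beyond the scatter. Compound 3 is estimated at 30000 nM, ranging from 10000 nM to 100000 nM, most likely again reported only as a limit.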

Compound 3, half-maximal inhibitory concentration: 322 nM
Beside the measured number, compound 3's estimate is 93-fold (1.97 log units) above it, and the stated range ends above it.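

This position, on an aromatic carbon between two ring nitrogen atoms, is one where this assay responds strongly: 2-(methoxymethyl)pyridin-4-yl in place of 6-methylpyridin-2-yl gives an at least 93-fold lower number from compound 2 to compound 3 (1.96 log units; beyond the scatter). Compound 3 is the only compound shown with a true number, and the full size of the step stays open, as compound 2 sits at a limit of the assay: the limit of > 30000 nM in this assay, at which 2 of the 3 values shown sit.

The change alters both the pyridine attachment and the side group, so the compounds shown do not separate the two. As far as these compounds go, whether a 2-methylpyridin-4-yl, or a 2-(aminomethyl)pyridin-4-yl, would hold this number remains open.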